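The source may report more compounds than this note shows. Statements on the series, on what has been measured and on what is new or still open speak of the compounds shown alone.

Compound 1 `CCCCCCCCCCCCNC(=O)[C@@H](NC(=O)c1ccco1)[C@@H](C)O` is the starting point. In a functional assay on A-431 cells (Homo sapiens) for cytotoxicity, read by MTT assay, with a stated time of 48 h (a higher number here means a weaker inhibitor, a lower number a stronger inhibitor), compound 1 gives 92400 nM. Compound 2 `CCCCCCCCCCCCNC(=O)[C@@H](NC(=O)c1cccs1)[C@@H](C)O` differs from it by thiophen-2-yl in place of furan-2-yl on a carbonyl carbon; in this assay compound 2 gives 16600 nM, and the step is a 5.6-fold lower number from compound 1 to compound 2 (0.75 log units; beyond the scatter). Compound 3 `CCCCCCCCCCCCCCNC(=O)[C@@H](NC(=O)c1ccco1)[C@@H](C)O` has a longer chain: the cores of compound 1 and compound 3 differ by ethyl in place of hydrogen on a saturated chain carbon, ten or more bonds along the chain from an amide-type nitrogen. In this assay compound 3 gives 190000 nM, and the step is a 2.1-fold higher number from compound 1 to compound 3 (0.31 log units; beyond the scatter). Compound 3 thus shows the highest number of the three, with compound 2 furthest from it. Compound 4 `CCCCCCCCCCCCCCNC(=O)[C@@H](NC(=O)c1cccs1)[C@@H](C)O` has not yet been measured. It stands to compound 3 as compound 2 stands to compound 1: the change is thiophen-2-yl in place of furan-2-yl on a carbonyl carbon, at the same place. This change occurs only once among the measured compounds, so the expectation rests on that single step. Compound 4 is expected to move from compound 3 by about a 5.6-fold lower number from compound 3 to compound 4 (0.75 log units; beyond the scatter), in line with a 5.6-fold lower number from compound 1 to compound 2 (0.75 log units; beyond the scatter). Compound 4 is therefore estimated at 34000 nM, with a range from 15000 nM to 80000 nM.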

Compound 4, half-maximal inhibitory concentration: 26500 nM
The estimate for compound 4 lay 1.3-fold (0.11 log units) above the measured number, and the stated range covers the measured number.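

In this assay, thiophen-2-yl in place of furan-2-yl on the core with the longer chain gives a 7.2-fold lower number from compound 3 to compound 4 (0.86 log units; beyond the scatter), and this step agrees with the one seen on the core of compound 1: the same change on two cores in this assay, a 5.6-fold lower number (0.75 log units; beyond the scatter) from compound 1 to compound 2 and a 7.2-fold lower number (0.86 log units; beyond the scatter) from compound 3 to compound 4, 1.3-fold (0.11 log units) apart, within the scatter of two such steps. The longer chain, read on the two thiophen-2-yl compounds, gives a 1.6-fold higher number from compound 2 to compound 4 (0.20 log units; within the scatter), and this step agrees with its furan-2-yl counterpart: the same change on two cores in this assay, a 2.1-fold higher number (0.31 log units; beyond the scatter) from compound 1 to compound 3 and a 1.6-fold higher number (0.20 log units; within the scatter) from compound 2 to compound 4, 1.3-fold (0.11 log units) apart, within the scatter of two such steps. Each change therefore carried from one core to the other without a difference beyond the scatter, but this rests on a single square of compounds in one assay and does not show that either step would hold on other cores or explain why it occurs.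

On these data alone, whether a phenyl ring in place of thiophen-2-yl, or a chain longer than that of compound 3, would follow the same steps stays open. Every compound shown also carries the hydroxyl group, and what it contributes remains open too.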